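Swapping a Bromine for a Nitro Group in Cytotoxicity

A few compounds are considered here, and "the series" means these few. Any claim that something is new, unique, unknown or untested is made for them only; others in the source may bear on it.

Compound 3 `COC(=O)c1ccc(NCc2cncn2Cc2ccc(Br)cc2)cc1-c1ccccc1` belongs to a small series built on one shared core, and three members have been examined in a toxicity assay on NIH3T3 cells (Mus musculus) for cytotoxicity, read by resazurin assay; a lower number here means that less compound is needed, a higher number that more compound is needed for the effect. For compound 1 `COC(=O)c1ccc(NCc2cncn2Cc2ccccc2C(C)(C)C)cc1-c1ccccc1` the result is "not determined" (no result reported). Compound 2 `COC(=O)c1ccc(NCc2cncn2Cc2ccc(Cl)cc2)cc1-c1ccccc1` gives 25000 nM in this assay. For compound 3 the reading in this assay is only a limit, > 10000 nM. The step that the limit leaves unreadable from compound 2 to compound 3 therefore cannot be sized, which follows from the limit of > 10000 nM in this assay, at which 1 of the 3 values shown sits. Compound 4 `COC(=O)c1ccc(NCc2cncn2Cc2ccccc2[N+](=O)[O-])cc1-c1ccccc1` differs from compound 3 by 2-nitrophenyl in place of 4-bromophenyl on a saturated chain carbon bound to an aromatic nitrogen. Among the measured compounds shown here, no measured step bears on this change, and nothing measured points in either direction, so no shift beyond the scatter is expected. Compound 4 is expected to give 25000 nM in this assay, within 10000 nM to 60000 nM. The step that the limit leaves unreadable from compound 3 to compound 4 is thus estimated to stay within the scatter.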

Compound 4, half-maximal effective concentration: 10000 nM
For compound 4 the middle estimate is 2.5-fold (0.40 log units) above the measured one; the measured number falls inside the stated range.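

In this assay, 2-nitrophenyl in place of 4-chlorophenyl gives a 2.5-fold lower number from compound 2 to compound 4 (0.40 log units; beyond the scatter). So replacing 4-chlorophenyl with 2-nitrophenyl on this saturated chain carbon does shift the reading, and less compound is needed for the effect. With 2-nitrophenyl in place of 4-bromophenyl, the data give a number no higher from compound 3 to compound 4 (the limit leaves the size open). Steps involving compound 3 cannot be read, because its reading is only a limit: the limit of > 10000 nM in this assay, at which 1 of the 4 values shown sits.

The compounds shown cannot separate the effect of the nitro group from that of its different ring position, since 2-nitrophenyl and 4-chlorophenyl differ in both. From the compounds shown here alone, how a phenyl ring carrying an amine or a carboxylic acid would read here also stays open.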